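From pyrrolidine to a larger two-ring amine

A few compounds are considered here, and "the series" means these few. Any claim that something is new, unique, unknown or untested is made for them only; others in the source may bear on it.

In a functional assay on HGC-27 cells (Homo sapiens) for antiproliferative activity, read by MTT assay, with stated times of 72 h and 4 h (on this read-out lower numbers stand for stronger inhibition and higher numbers for weaker inhibition), compound 1 `COc1ncc(-c2nc3c(N4CCC(OC)CC4)ncnc3s2)cc1NS(=O)(=O)c1ccc(F)cc1F` gives 74 nM, whereas compound 2 `COc1ncc(-c2nc3c(N4CCCC4)ncnc3s2)cc1NS(=O)(=O)c1ccc(F)cc1F` gives 1200 nM, the higher of the two numbers and therefore the weaker inhibition. Compound 3 `COc1ncc(-c2nc3c(N4CC5CCCC5C4)ncnc3s2)cc1NS(=O)(=O)c1ccc(F)cc1F` keeps the rest of compound 2 and alters only the amine group on an aromatic carbon of the shared core: a group of 8 heavy atoms (7 carbon, 1 nitrogen; one five-membered non-aromatic ring of carbon only, one five-membered non-aromatic ring with 1 hetero atom) in place of a group of 5 heavy atoms (4 carbon, 1 nitrogen; one five-membered non-aromatic ring with 1 hetero atom), on an aromatic carbon. Going by the values given here, only one measured step bears on this change, and it involves the same place: a 16-fold higher number from compound 1 to compound 2 (1.21 log units; beyond the scatter). That large step links the pyrrolidin-1-yl group of compound 2 to a group with a six-membered ring and a methoxy substituent, which compound 3 does not carry, so it is only a loose guide. With compound 1 at 74 nM, a move away from pyrrolidin-1-yl to a larger group is expected to lower the number in this assay, but by less than the full size of that step. The expected change is a 3.4-fold lower number from compound 2 to compound 3 (0.54 log units; beyond the scatter). For compound 3, the estimated value is 350 nM, with an expected range of 100 nM to 1200 nM.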

Compound 3, half-maximal inhibitory concentration: 310 nM
Compound 3: middle estimate off by 1.1-fold (0.05 log units), on the high side, and the stated range covers the measured number.
By their numbers in this assay, from the lowest: compound 1; then compound 3; then compound 2.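

In this assay, replacing the pyrrolidin-1-yl group on this aromatic carbon of the shared core with the two-ring amine gives a 3.9-fold lower number from compound 2 to compound 3 (0.59 log units; beyond the scatter) and shows that the number can fall at this position without a six-membered ring or an oxygen in the entering group. The second comparison is between two groups with the same count of 8 heavy atoms, one with two five-membered rings and the other with a six-membered ring and a methoxy substituent, and it gives a 4.2-fold higher number from compound 1 to compound 3 (0.62 log units; beyond the scatter), so the heavy-atom count alone does not set the number among these three compounds. No measurement given here accounts for either step.

The compounds shown do not separate the six-membered ring of compound 1 from its methoxy substituent, and a plain piperidin-1-yl group on this carbon would test the ring alone. A morpholin-4-yl group, which places the oxygen within the ring, would show whether the oxygen of compound 1 must sit on a substituent for the number to stay that low.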